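This account rests on a few compounds, and the source may have more. Where it says the series, first, only, none or still open, it means among the compounds named here.

Of the compounds shown here, three sharing one core have been measured in a physicochemical assay for pharmacokinetics; a higher number here means that the compound lasts longer, a lower number that the compound disappears faster. Compound 1 `CC(NC(=O)N1C(=O)c2ccccc2S1(=O)=O)c1ccccc1` carries a methyl on a saturated chain carbon, compound 2 `O=C(NCc1ccccc1F)N1C(=O)c2ccccc2S1(=O)=O` carries a fluoro on an aromatic carbon, and compound 3 `O=C(NCc1ccccc1)N1C(=O)c2ccccc2S1(=O)=O` has hydrogen in both places. Compound 1 gives > 166 h, which is a limit and not a number. Compound 2 gives > 166 h, also a limit. Compound 3 gives > 166 h, again a limit. Compound 3 therefore has no number of its own, and the whole set is summed up by the limit of > 166 h in this assay, at which 3 of the 3 values shown sit.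

The change now followed leads to compound 4 `COc1ccccc1CNC(=O)N1C(=O)c2ccccc2S1(=O)=O`, with methoxy in place of hydrogen on an aromatic carbon, ortho to a large group, so that phenyl becomes 2-methoxyphenyl (methoxy in place of hydrogen on an aromatic carbon). The closest measured change is a step that the two limits leave unreadable from compound 2 to compound 3, which also concerns an aromatic carbon. The other is a step that the two limits leave unreadable from compound 1 to compound 3. Neither has a readable size, so the expectation rests on all three compounds sharing the limit, and no step beyond the scatter is expected in this assay, in either direction. The expected step is a step that the limit leaves unreadable from compound 3 to compound 4. The half-life estimated for compound 4 is 200 h, with an expected range from 90 h to 500 h.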

Compound 4, half-life: > 166 h
Compound 4: no number, only a limit; the forecaster's own chance of this, stated with the estimate: 75%; the middle value is on the limit's open side.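

Going by these compounds alone, compound 4, like compound 2 and compound 3, gives only a limit in this assay, so neither the step from compound 3 to compound 4 nor the one from compound 2 to compound 4 can be read. The compounds shown leave open how long any of them actually lasts and whether methoxy, fluoro or methyl shifts the half-life at all, for the set offers one result only: the limit of > 166 h in this assay, at which 4 of the 4 values shown sit.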